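The source may hold more compounds than are shown below. What is called first, only, known or untested is meant among the compounds shown, and "the series" means these compounds.

The measured compounds and their values in a functional assay on MCF7 cells (Homo sapiens) for antiproliferative activity, read by MTT assay, with a stated time of 72 h; on this read-out lower numbers stand for stronger inhibition and higher numbers for weaker inhibition:

Compound 1, `COc1cc(-n2cnc3ccc(-c4cccc(F)c4)cc32)cc(OC)c1OC`, gives 2350 nM.
Compound 2, `COc1cc(-n2cnc3ccc(-c4cccc(C)c4C)cc32)cc(OC)c1OC`, gives 2150 nM.
Compound 3, `COc1ccc(-c2ccc3ncn(-c4cc(OC)c(OC)c(OC)c4)c3c2)cc1`, gives 210 nM.

Compound 3 stands lowest of the three numbers. Its nearest neighbour is compound 2, reached by the step of a 10-fold lower number from compound 2 to compound 3 (1.01 log units; beyond the scatter), and its furthest is compound 1, reached by the step of an 11-fold lower number from compound 1 to compound 3 (1.05 log units; beyond the scatter); both steps are beyond the scatter and large. Compounds 1 and 2 sit within the scatter of each other, as the step of a 1.1-fold lower number from compound 1 to compound 2 (0.04 log units; within the scatter) shows.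

Compound 4 is `COc1ccccc1-c1ccc2ncn(-c3cc(OC)c(OC)c(OC)c3)c2c1`. It differs from compound 3 in one place: 2-methoxyphenyl in place of 4-methoxyphenyl on an aromatic carbon.

Going by the values given here, the steps that bear on this change are the two leading into compound 3, an 11-fold lower number from compound 1 to compound 3 (1.05 log units; beyond the scatter) and a 10-fold lower number from compound 2 to compound 3 (1.01 log units; beyond the scatter): both show that the 4-methoxyphenyl ring carries a large advantage over the 3-fluorophenyl and the 2,3-dimethylphenyl rings. Among the compounds with values here, no measured step shows the methoxy group moved to another position of that ring. Within the data shown here, because the only low number belongs to the 4-methoxyphenyl compound 3 at 210 nM, while both other aryl patterns fall near compound 1 at 2350 nM, the expectation is that compound 4 loses potency, with a step of a 5.7-fold higher number from compound 3 to compound 4 (0.76 log units; beyond the scatter) expected. Compound 4 is therefore estimated at 1200 nM, in a range from 300 nM to 4500 nM.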

Compound 4, half-maximal inhibitory concentration: 1750 nM
Compound 4: middle estimate off by 1.5-fold (0.16 log units), on the low side; low and high end bracket the measured number.
By their numbers in this assay, from the lowest: compound 3; then compounds 4, 2 and 1 (each within the scatter of the next).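

In this assay, moving the methoxy group within the aryl ring, with the same atoms joined differently, gives an 8.3-fold higher number from compound 3 to compound 4 (0.92 log units; beyond the scatter), so the methoxy group alone does not secure the low number of compound 3; its place on the ring matters as well. Compound 4 also falls in with the two earlier compounds, with a 1.2-fold lower number from compound 2 to compound 4 (0.09 log units; within the scatter) and a 1.3-fold lower number from compound 1 to compound 4 (0.13 log units; within the scatter), both steps within the scatter, so among the four aryl rings shown only the 4-methoxyphenyl of compound 3 stands apart, and the 2-methoxyphenyl, 2,3-dimethylphenyl and 3-fluorophenyl rings cannot be told apart in this assay. No measurement at hand accounts for the loss on moving the methoxy group.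

From the compounds shown here alone, it remains open whether the advantage of compound 3 belongs to the methoxy group itself or would survive with a hydroxyl, an ethoxy or an amine in its place on the ring. Going by these compounds, it also remains open whether the gap between compound 3 and compound 4 would hold in cell lines other than the one tested here.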